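Removing the acetyl ester from compound 3

The source may hold more compounds than are shown below. What is called first, only, known or untested is meant among the compounds shown, and "the series" means these compounds.

In a functional assay on THP-1 cells (Homo sapiens) for cytotoxicity, tested at 10 uM (on this read-out higher numbers stand for more inhibition at the one concentration tested (going by the name of the read-out) and lower numbers for less inhibition), compound 3 , `CC(=O)OCCCc1cnc2ncnn2c1`, gives 0%. Compound 1 , `CCO[C@@H](C1=CC2C(c3ccc(O)cc3)=NN(c3ccccc3)C2N=C1)[C@H](O)[C@@H](O)CO`, gives 5%, and compound 2 , `COc1ccc(-c2nn(-c3ccccc3)c3ncc(CCCO)cc23)cc1`, gives 10%; both of these numbers lie within the usual scatter of the reading of compound 3, so the three compounds cannot be told apart on this read-out. Compound 4 , `OCCCc1cnc2ncnn2c1`, differs from compound 3 by the following: hydrogen in place of acetyl on an oxygen on a saturated carbon. Acetoxy becomes hydroxy on the three-carbon chain. Among the compounds with values here, with compound 3 at the bottom of the scale and no measured step of this kind to lean on, the step from compound 3 to compound 4 is expected to stay within the scatter, a number 3 percentage points higher from compound 3 to compound 4 (within the scatter). Compound 4 is estimated to give 3%, between -10% and 15%.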

Compound 4, a percentage reported as inhibition, at one concentration (the size of the read-out at that concentration, not a potency): 0%
Beside the measured number, compound 4's estimate is 3 percentage points above it; low and high end bracket the measured number.
By their numbers in this assay, from the lowest: compounds 3, 4, 1 and 2 (each within the scatter of the next).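

In this assay, replacing acetoxy with hydroxy on the three-carbon chain gives no change at the digits printed from compound 3 to compound 4 (within the scatter). Within the data shown here, this is the first step measured at this position, and it shows that removing the acetyl group from the oxygen leaves the reading of this small compound at the bottom of the scale. No available evidence bears on this result. Still open, on these data alone, is whether an amine or a carboxylic acid in place of the hydroxy, or a longer chain, would read any differently. As far as these compounds go, a step on a larger core, such as that of compound 2, also remains open.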